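The source may report more compounds than this note shows. Statements on the series, on what has been measured and on what is new or still open speak of the compounds shown alone.

Working notes on the series.

The shared core is common to all three members considered here. Compound 1 `CN(C)CCn1cnnc1-c1cc(Oc2ccc(NC(=O)N/N=C/c3cc(C(C)(C)C)cc(C(C)(C)C)c3O)cc2F)ccn1` and compound 2 `CN(C)CCn1cnnc1-c1cc(Oc2ccc(NC(=O)N/N=C/c3ccccc3O[N+](=O)[O-])cc2F)ccn1` have been run in a functional assay on U-87MG ATCC cells (Homo sapiens) for cytotoxicity, read by MTT assay, with a stated time of 72 h; a lower number here means a stronger inhibitor, a higher number a weaker inhibitor. In this assay compound 1 gives 520 nM. In this assay compound 2 gives 7150 nM, the higher of the two numbers, and the gap to compound 1 lies beyond the usual scatter, so compound 2 stands as the weaker of the two measured inhibitors.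

Compound 3 `CN(C)CCn1cnnc1-c1cc(Oc2ccc(NC(=O)N/N=C/c3ccc(O)cc3O)cc2F)ccn1` has not yet been measured. It differs from compound 2 in one place: 2,4-dihydroxyphenyl in place of 2-(nitrooxy)phenyl on a carbon with a double bond to nitrogen. Nothing in the measured pair isolates this exact change, so the expectation rests on what the two values show.

Compound 1, whose ring at that position also carries a hydroxy, gives 520 nM, while compound 2 gives 7150 nM; on that basis the step from compound 2 to compound 3 is expected to be a 4.0-fold lower number from compound 2 to compound 3 (0.60 log units; beyond the scatter), a move to a lower number beyond the scatter, though short of the value of compound 1. Compound 3 is therefore estimated at 1800 nM in this assay, with a range from 600 nM to 5500 nM.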

Compound 3, half-maximal inhibitory concentration: 15400 nM
Compound 3: middle estimate off by 8.6-fold (0.93 log units), on the low side, outside the stated range (above it).
By their numbers in this assay, from the lowest: compound 1; then compound 2; then compound 3.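

In this assay, 2,4-dihydroxyphenyl in place of 2-(nitrooxy)phenyl on a carbon with a double bond to nitrogen gives a 2.2-fold higher number from compound 2 to compound 3 (0.33 log units; beyond the scatter), a modest step, so hydroxy groups on this ring do not by themselves bring the number down. A hydroxy is present on the ring of compound 1, at 520 nM, and also on the ring of compound 3, at 15400 nM, so the printed values show that the presence of a hydroxy does not settle the number at this position and that the group must be read as a whole. Within the data shown here, nothing measured so far accounts for the direction of this step.

Open, as far as these compounds go, is how each hydroxy of the 2,4-dihydroxyphenyl group contributes on its own, and whether the tert-butyl groups on the ring of compound 1 go with its lower number in this assay. Also open, from the compounds shown here alone, is how a phenyl ring at this position carrying an amine or a carboxylic acid would read in this assay against these three values.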